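Extending the amide substituent from ethyl to isopropyl

This account rests on a few compounds, and the source may have more. Where it says the series, first, only, none or still open, it means among the compounds named here.

Measured compounds:
compound 1 `CNC(=O)/C=C1/COc2cc(OS(=O)(=O)c3cccc(Cl)c3)ccc21`: 0%
compound 2 `CCNC(=O)/C=C1/COc2cc(OS(=O)(=O)c3cccc(Cl)c3)ccc21`: 0%

In an assay (strain Sprague-Dawley) for inhibition of Amine oxidase [flavin-containing] B (Rattus norvegicus), read by spectrophotometry, with a stated time of 5 min, tested at 10 uM (on this read-out higher numbers stand for more inhibition at the one concentration tested (going by the name of the read-out) and lower numbers for less inhibition), compound 1 gives 0%. Compound 2, carrying an ethyl rather than a methyl on the amide nitrogen, gives in this assay a value of 0%. Among the compounds with values here, the only measured step, no change at the digits printed from compound 1 to compound 2 (within the scatter), therefore shows no movement within the scatter, and compound 2 stands level with compound 1 on the numbers available; neither compound shows any inhibition at the concentration tested.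

Compound 3 `CC(C)NC(=O)/C=C1/COc2cc(OS(=O)(=O)c3cccc(Cl)c3)ccc21` is the next member of the same series. Its difference from compound 2 is methyl in place of hydrogen on a saturated chain carbon bound to an amide-type nitrogen and a saturated chain carbon. Within the data shown here, the one step that bears on this change is the earlier one, in which a methyl was likewise added to a saturated chain carbon bound to an amide-type nitrogen, and that step was flat. Nothing in the data points to a departure from the shared baseline, so the step of no change at the digits printed from compound 2 to compound 3 (within the scatter) is expected to stay within the scatter. Compound 3 is accordingly estimated at 0%, with a range from 0% to 12%.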

Compound 3, a percentage reported as inhibition, at one concentration (the size of the read-out at that concentration, not a potency): 1%
The estimate for compound 3 lay 1 percentage points below the measured number; the measured number falls inside the stated range.
By their numbers in this assay, from the lowest: compounds 1, 2 and 3 (each within the scatter of the next).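

In this assay, within the data shown here, the step from ethyl to isopropyl, which places a methyl on a saturated chain carbon bound to an amide-type nitrogen and a saturated chain carbon, comes with a number 1 percentage points higher from compound 2 to compound 3 (within the scatter) and is the first change at this position to put a second carbon on that chain carbon. Read over the whole series, isopropyl in place of methyl on the amide-type nitrogen gives a number 1 percentage points higher from compound 1 to compound 3 (within the scatter) as well, so neither lengthening the substituent nor branching it separates the compounds. All three substituents sit close to no inhibition at the one concentration tested, which means the series shows a flat stretch near the bottom of the read-out and no trend that could be followed along the substituent.

As far as these compounds go, it remains open whether a longer chain, a benzyl group or a chain ending in an amine on the amide nitrogen would give any measurable inhibition on the shared core. No measurement offered here speaks to what lies behind these readings.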